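The source may report more compounds than this note shows. Statements on the series, on what has been measured and on what is new or still open speak of the compounds shown alone.

Measured in a functional assay on A2780 cells (Homo sapiens) for inhibition, with a stated time of 72 h; a lower number here means a stronger inhibitor, a higher number a weaker inhibitor:
- compound 1 `CC(=O)O[C@@]1([C@@H]2/C(C)=C(/O)C(=O)C3=C(C)[C@@H](OC(=O)[C@H](O)[C@H](C=C(C)C)NC(=O)OC(C)(C)C)C[C@@](O)([C@H]2OC(=O)c2cccc(Cl)c2)C3(C)C)CO[C@@H]1CCO`: 4 nM
- compound 2 `CC(=O)O[C@@]1([C@@H]2/C(C)=C(/O)C(=O)C3=C(C)[C@@H](OC(=O)[C@H](O)[C@H](CC(C)C)NC(=O)OC(C)(C)C)C[C@@](O)([C@H]2OC(=O)c2cccc(Cl)c2)C3(C)C)CO[C@@H]1CCO`: 4.1 nM

Going by the values given here, only these two numbers exist so far, and compound 1 sits level with its sole neighbour, since a 1.0-fold higher number from compound 1 to compound 2 (0.01 log units; within the scatter). Neither compound ranks ahead of the other.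

Compound 3 `COc1cccc(C(=O)O[C@H]2[C@H]([C@]3(OC(C)=O)CO[C@@H]3CCO)/C(C)=C(/O)C(=O)C3=C(C)[C@@H](OC(=O)[C@H](O)[C@H](C=C(C)C)NC(=O)OC(C)(C)C)C[C@]2(O)C3(C)C)c1` keeps the core of compound 1 and has methoxy in place of chloro on an aromatic carbon, meta to a large group, so that 3-chlorophenyl becomes 3-methoxyphenyl (methoxy in place of chloro on an aromatic carbon). Among the compounds with values here, no measured pair tests a change at this aromatic carbon. Within the data shown here, the one measured step lies elsewhere in the molecule, at the isobutyl and 2-methylprop-1-en-1-yl groups, and bears on the question only indirectly. It shows that one change in this series left this assay within the scatter, and it says nothing about the aromatic ring.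

A step beyond the scatter is therefore not expected, and the data give no direction, so the range stays wide on both sides. The expected step is a 1.3-fold higher number from compound 1 to compound 3 (0.10 log units; within the scatter). The estimated value for compound 3 is 5 nM, with an expected range from 2 nM to 14 nM.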

Compound 3, half-maximal inhibitory concentration: 5.7 nM
Compound 3: middle estimate off by 1.1-fold (0.06 log units), on the low side; measured number inside the range.
By their numbers in this assay, from the lowest: compounds 1, 2 and 3 (each within the scatter of the next).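

This aromatic carbon now has its first measured change: in this assay the move from 3-chlorophenyl to 3-methoxyphenyl gives a 1.4-fold higher number from compound 1 to compound 3 (0.15 log units; within the scatter) and so leaves the reading within the scatter. Across this pair, therefore, a group of two heavy atoms with one hydrogen-bond acceptor stands in for a group of one heavy atom with none, and the number in this assay stays level with that of compound 1. This adds a second single change within the scatter, now on the aromatic ring rather than at the isobutyl and 2-methylprop-1-en-1-yl groups, and no measurement at hand offers an explanation for the level reading.

Only chloro and methoxy are shown at this carbon, so it remains open whether an amine, a carboxylic acid or a longer chain such as butoxy would also stay level with compound 1 in this assay or would leave the scatter in either direction. Also open, as far as these compounds go, is whether isobutyl in place of 2-methylprop-1-en-1-yl would read the same on the 3-methoxyphenyl compound as it did on the 3-chlorophenyl one.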